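The source may hold more compounds than are shown below. What is called first, only, known or untested is meant among the compounds shown, and "the series" means these compounds.

Of the compounds shown here, two built on the same core have so far been tested in a functional assay on HepG2 cells (Homo sapiens) for antiproliferative activity, read by MTT assay, with a stated time of 48 h; on this read-out lower numbers stand for stronger inhibition and higher numbers for weaker inhibition. Compound 1 `CCc1ccccc1-n1nncc1CN1C(=O)C2(C(C#N)=C(N)Oc3c(N)cc4nc5ccccc5nc4c32)c2ccccc21` carries a 2-ethylphenyl on an aromatic nitrogen, and in this assay compound 1 gives 17900 nM. Compound 2 `Cc1ccc(-n2nncc2CN2C(=O)C3(C(C#N)=C(N)Oc4c(N)cc5nc6ccccc6nc5c43)c3ccccc32)cc1C` carries a 3,4-dimethylphenyl at that same place. For compound 2 this assay reports only a limit, > 50000 nM, so its true number is not known. Among the measured compounds shown here, the one measured step, an at least 2.7-fold higher number from compound 1 to compound 2 (0.44 log units; beyond the scatter), can be read only against (the limit of > 50000 nM in this assay, at which 1 of the 2 values shown sits). Compound 3 `Cc1ccc(Cl)cc1-n1nncc1CN1C(=O)C2(C(C#N)=C(N)Oc3c(N)cc4nc5ccccc5nc4c32)c2ccccc21` has not yet been measured; it differs from compound 2 in a single place: 5-chloro-2-methylphenyl in place of 3,4-dimethylphenyl on an aromatic nitrogen. For the measured compounds named here, the only measured step that bears on this change is an at least 2.7-fold higher number from compound 1 to compound 2 (0.44 log units; beyond the scatter), which shows that exchanging one such phenyl for another at this position can shift the number by at least a modest amount. Since compound 2 sits at a limit, the step to compound 3 is expected to be downward, an at least 1.6-fold lower number from compound 2 to compound 3 (0.22 log units; that floor lies within the scatter), though it may again fall at a limit. Compound 3 is estimated at 30000 nM, within a range of 12000 nM to 60000 nM.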

Compound 3, half-maximal inhibitory concentration: 17300 nM
Beside the measured number, compound 3's estimate is 1.7-fold (0.24 log units) above it; the range from low to high includes it.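

Changing the phenyl on the aromatic nitrogen can also bring the number back down: 5-chloro-2-methylphenyl in place of 3,4-dimethylphenyl gives an at least 2.8-fold lower number from compound 2 to compound 3 (0.46 log units; beyond the scatter). This is only a floor for the real size of the step, as compound 2 carries a limit and not a number: the limit of > 50000 nM in this assay, at which 1 of the 3 values shown sits. The other new comparison gives a 1.0-fold lower number from compound 1 to compound 3 (0.01 log units; within the scatter), so 2-ethylphenyl and 5-chloro-2-methylphenyl cannot be told apart here; among these three compounds, the two groups with a 2-ethyl or 2-methyl in their names give measured numbers, and 3,4-dimethylphenyl, which has neither, stands at the limit, although three compounds are too few to establish a rule.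

The compounds shown do not separate the contribution of the chlorine from that of the methyl in 5-chloro-2-methylphenyl, so neither can be credited with the result on its own. They also leave open how this position responds to a phenyl carrying an amine or a carboxylic acid, or to a longer chain in place of the ethyl in 2-ethylphenyl.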